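Tolerance in the series: from compound 2 to compound 3

The source may report more compounds than this note shows. Statements on the series, on what has been measured and on what is new or still open speak of the compounds shown alone.

Among the measured compounds shown here, in an ADME assay on HepG2 2.2.15 cells (Homo sapiens) for cytotoxicity, read by MTT assay (a higher number here means that more compound is tolerated, a lower number that less compound is tolerated), compound 2 `C=C1CC[C@@H]2[C@](C)(COC(=O)/C=C/c3cccc(Cl)c3)[C@H](O)CC[C@@]2(C)[C@@H]1/C=C/C1=CCOC1=O` gives 147000 nM, the only actual number so far. Compound 1 `C=C1CC[C@@H]2[C@](C)(COC(=O)/C=C/c3cccc(OC)c3)[C@H](O)CC[C@@]2(C)[C@@H]1/C=C/C1=CCOC1=O` reads > 1970000 nM, which is a limit of the assay. For the measured compounds named here, the one measured step, an at least 13-fold lower number from compound 1 to compound 2 (1.12 log units; beyond the scatter), is large. That step is chloro in place of methoxy on an aromatic carbon, so it bears on the next change only indirectly. Compound 3 `C=C1CC[C@@H]2[C@](C)(COC(=O)c3cccnc3)[C@H](O)CC[C@@]2(C)[C@@H]1/C=C/C1=CCOC1=O` differs from compound 2 as follows: pyridin-3-yl in place of 2-(3-chlorophenyl)ethenyl on a carbonyl carbon. In words, this is pyridin-3-yl in place of 2-(3-chlorophenyl)ethenyl on a carbonyl carbon, so the chloro leaves with that group. On the strength of an at least 13-fold lower number from compound 1 to compound 2 (1.12 log units; beyond the scatter) alone, a higher number is expected in this assay, though this is thin support. The expected step is a 4.1-fold higher number from compound 2 to compound 3 (0.61 log units; beyond the scatter). For compound 3 the estimate is 600000 nM, with an expected range of 150000 nM to 2000000 nM.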

Compound 3, half-maximal cytotoxic concentration: 113000 nM
The estimate for compound 3 lay 5.3-fold (0.73 log units) above the measured number; the whole stated range lies above it.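

In this assay, pyridin-3-yl and 2-(3-chlorophenyl)ethenyl on this carbonyl carbon read alike, with a 1.3-fold lower number from compound 2 to compound 3 (0.11 log units; within the scatter), although the entering group has no chloro and no double bond outside aromatic rings. Measured against the 2-(3-methoxyphenyl)ethenyl group, the same pyridin-3-yl gives an at least 17-fold lower number from compound 1 to compound 3 (1.24 log units; beyond the scatter), so among the three compounds only compound 1 stands apart. The true size of that step stays open because compound 1 reads only as a limit: the limit of > 1970000 nM in this assay, at which 1 of the 3 values shown sits.

The compounds shown leave open whether the reading of compound 1 depends on the methoxy group alone or on the whole 2-(3-methoxyphenyl)ethenyl group. An unsubstituted 2-phenylethenyl group, or an amine in place of the methoxy on the same aromatic ring, would separate these two readings.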